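Cyclohexyl ketone replaces a chlorophenyl ketone in a benzoxaborole series

This account rests on a few compounds, and the source may have more. Where it says the series, first, only, none or still open, it means among the compounds named here.

Three benzoxaborole-bearing compounds have been tested in an ADME assay on L929 cells (Mus musculus) for cytotoxicity, read by resazurin assay, with a stated time of 72 h; a lower number here means a stronger inhibitor, a higher number a weaker inhibitor. Compound 1 `OB1OCc2ccc(-n3cc(Sc4ccc(Cl)cc4)c4ccccc43)cc21` gives a value that is a limit of the assay, > 10 ug/mL. Compound 2 `OB1OCc2ccc(-n3cccc3Sc3ccc(Cl)c(Cl)c3)cc21` likewise gives only a limit, > 10 ug/mL. Compound 3 `O=C(c1cccc(Cl)c1)c1ccn(-c2ccc3c(c2)B(O)OC3)c1` also returns a limit, > 10 ug/mL. Compound 3 thus stands where all three measured compounds sit, at the limit of > 10 ug/mL in this assay, at which 3 of the 3 values shown sit. Compound 4 `O=C(c1ccn(-c2ccc3c(c2)B(O)OC3)c1)C1CCCCC1` differs from compound 3 by cyclohexyl in place of 3-chlorophenyl on a carbonyl carbon. Going by the values given here, no measured pair shows this change, so the step from compound 3 to compound 4 in this assay can only be expected, and it is expected to be small or none beyond the scatter, with compound 4 most likely again reported as a limit; the estimated step is a step that the limit leaves unreadable from compound 3 to compound 4. Compound 4 is estimated at 20 ug/mL, within 8 ug/mL to 60 ug/mL.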

Compound 4, half-maximal inhibitory concentration: > 10 ug/mL
Compound 4: a limit, no number (the forecaster's own chance of this, stated with the estimate: 80%); the middle value is on the limit's open side.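

Compound 3 and compound 4 both stand only as limits in this assay, so no step between them can be read: the limit of > 10 ug/mL in this assay, at which 4 of the 4 values shown sit.

The compounds shown leave open whether any of them differs from the others in this cytotoxicity read-out.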